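From Ethyl to Methylsulfanyl: A Small Expected Step

The source may hold more compounds than are shown below. What is called first, only, known or untested is meant among the compounds shown, and "the series" means these compounds.

In a functional assay on A549 cells (Homo sapiens) for inhibition, read by MTT assay, with a stated time of 48 h (a lower number here means a stronger inhibitor, a higher number a weaker inhibitor), compound 1 (`CCc1ccc(-c2nc3ccccn3c2Sc2ccccc2)cc1`) gives 56200 nM and shares the high end of the three measured numbers with compound 2 (`Cc1ccc(-c2nc3ccccn3c2Sc2ccccc2)cc1`), which gives 94300 nM within the scatter of compound 1. Compound 3 (`c1ccc(Sc2c(-c3cccc4ccccc34)nc3ccccn23)cc1`) gives 17900 nM and so stands clearly lower than compound 1.

The step under consideration leads to compound 4 (`CSc1ccc(-c2nc3ccccn3c2Sc2ccccc2)cc1`), which has methylsulfanyl in place of ethyl on an aromatic carbon para to a large group. Within the data shown here, only one measured step touches this group. It is a 1.7-fold higher number from compound 1 to compound 2 (0.22 log units; within the scatter) and replaces a methyl of the ethyl chain with hydrogen. Among the measured compounds shown here, no measured compound carries sulfur at this carbon, so that step is only a loose guide. Compound 3 differs from compound 1 by a larger group, and its value offers no direct reading for this swap.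

For the measured compounds named here, with the sole relevant step (a 1.7-fold higher number from compound 1 to compound 2 (0.22 log units; within the scatter)) inside the scatter, no shift in either direction is favoured. The estimated 1.1-fold lower number from compound 1 to compound 4 (0.05 log units; within the scatter) is expected to stay within the scatter. For compound 4 the estimated value in this assay is 50000 nM with 22000 nM to 110000 nM as the expected range.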

Compound 4, half-maximal inhibitory concentration: 13600 nM
For compound 4 the middle estimate is 3.7-fold (0.57 log units) above the measured one, and the stated range ends above it.
By their numbers in this assay, from the lowest: compounds 4 and 3 (each within the scatter of the next); then compounds 1 and 2 (each within the scatter of the next).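

In this assay the carbon that carries this group proves responsive: swapping ethyl for methylsulfanyl gives a 4.1-fold lower number from compound 1 to compound 4 (0.62 log units; beyond the scatter) and is joined by the swap of methyl for methylsulfanyl, which gives a 6.9-fold lower number from compound 2 to compound 4 (0.84 log units; beyond the scatter) on the same carbon. Among these compounds, the earlier compounds could not show this, as their only step here, a 1.7-fold higher number from compound 1 to compound 2 (0.22 log units; within the scatter) in the shorter chain, stays within the scatter and so showed no response to a change of the carbon chain at this place. The new steps show that a group with the same heavy-atom count as ethyl can still move the number beyond the scatter once sulfur enters, although nothing available here accounts for the shift.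

The compounds shown leave open whether sulfur itself matters, since they do not tell how methoxy, with oxygen in its place, or a longer chain such as ethylsulfanyl would read at this carbon. They also leave open whether an amine or a carboxylic acid would be tolerated there, and whether the same swap would lower the number on a compound carrying the larger group of compound 3.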